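The source may report more compounds than this note shows. Statements on the series, on what has been measured and on what is new or still open speak of the compounds shown alone.

Measured so far in a functional assay on HeLa cells (Homo sapiens) for inhibition, read by MTT assay, with a stated time of 72 h; a higher number here means a weaker inhibitor, a lower number a stronger inhibitor:
Compound 1 `COc1cc(OC)c(OC)cc1/C=C/C(=O)c1ccccc1`: > 150000 nM (a limit)
Compound 2 `COc1cc(OC)c(OC)cc1/C=C/C(=O)c1ccc(Cl)c([N+](=O)[O-])c1`: 16500 nM
Compound 3 `COc1cc(OC)c(OC)cc1/C=C/C(=O)c1cccc(C(F)(F)F)c1`: > 150000 nM (a limit)

Compound 3 gives only a limit, not a number, and it stands at the limit of > 150000 nM in this assay, at which 2 of the 3 values shown sit. The next compound, compound 4 `COc1cc(OC)c(OC)cc1/C=C/C(=O)c1cccc([N+](=O)[O-])c1`, carries nitro in place of trifluoromethyl on an aromatic carbon, meta to a large group (nitro in place of trifluoromethyl on an aromatic carbon).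

For the measured compounds named here, the only measured single-place step that bears on this change is a step that the two limits leave unreadable from compound 1 to compound 3, so it sets no size to carry over. Going by the values given here, the sole number comes from compound 2, which carries a nitro group together with a chlorine and gives 16500 nM. Compound 4 has the nitro group without that chlorine, so a result at the limit remains possible. Even so, in this assay a shift towards a lower number is expected, resting on compound 2 at 16500 nM, with the size poorly defined. The expected step is an at least 2.5-fold lower number from compound 3 to compound 4 (0.39 log units; beyond the scatter). For compound 4 the estimated value is 60000 nM, with an expected range of 15000 nM to 150000 nM.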

Compound 4, half-maximal inhibitory concentration: 130000 nM
The estimate for compound 4 lay 2.2-fold (0.34 log units) below the measured number; the measured number falls inside the stated range.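

For the compounds shown here, compound 4 is the first compound here that carries nitro without chlorine, and in this assay compound 4 gives a number, 130000 nM, so nitro alone on this aromatic carbon is enough for a readable value. The comparisons with compound 1 and compound 3 start from limits. They give only floors: an at least 1.1-fold lower number from compound 1 to compound 4 (0.06 log units; that floor lies within the scatter), and an at least 1.1-fold lower number from compound 3 to compound 4 (0.06 log units; that floor lies within the scatter), so neither nitro in place of hydrogen nor nitro in place of trifluoromethyl is shown to go beyond the scatter. Going by these compounds alone, the one step that does go beyond it is the loss of chloro with nitro kept, a 7.9-fold higher number from compound 2 to compound 4 (0.90 log units; beyond the scatter), which ties the stronger value of compound 2 to the chloro group within this pair.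

As far as these compounds go, how far compound 1 and compound 3 actually lie from compound 4 stays open, because neither has a number: the limit of > 150000 nM in this assay, at which 2 of the 4 values shown sit. Also open is whether chloro without nitro would give a number on the shared core, and how an amine or a carboxylic acid in place of nitro would read in this assay.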